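Chloro for fluoro: what compound 4 may show

The source may report more compounds than this note shows. Statements on the series, on what has been measured and on what is new or still open speak of the compounds shown alone.

Among the measured compounds shown here, in a functional assay on NCI-H460 cells (Homo sapiens) for inhibition, read by CCK-8 assay, with a stated time of 72 h (a higher number here means a weaker inhibitor, a lower number a stronger inhibitor), three compounds have numbers so far. Compound 1 (`Nc1ccccc1NC(=O)c1ccc(CNC(=O)c2n[nH]cc2NC(=O)c2ccccc2Cl)cc1`) gives 6360 nM, compound 2 (`O=C(NO)c1ccc(CNC(=O)c2n[nH]cc2NC(=O)c2c(Cl)cccc2Cl)cc1`) gives 10600 nM, and compound 3 (`O=C(NO)c1ccc(CNC(=O)c2n[nH]cc2NC(=O)c2ccccc2F)cc1`) gives 23700 nM. That last value is the highest of the three, which makes compound 3 the weakest inhibitor of the set, with compound 2 as its nearest neighbour on the numbers.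

Compound 4 (`O=C(NO)c1ccc(CNC(=O)c2n[nH]cc2NC(=O)c2ccccc2Cl)cc1`) has not yet been measured. It differs from compound 3 in one place: chloro in place of fluoro on an aromatic carbon.

For the measured compounds named here, one measured step bears on this change: a 2.2-fold higher number from compound 2 to compound 3 (0.35 log units; beyond the scatter). It is modest, with 2-fluorophenyl in place of 2,6-dichlorophenyl on a carbonyl carbon. Read in reverse, it runs toward a lower number on going from the 2-fluorophenyl group to a chlorinated one. Compound 1 also carries the 2-chlorophenyl group and gives 6360 nM, but it differs from compound 4 elsewhere, so it offers no single-place comparison.

A small move toward a lower number is therefore expected in this assay, no larger than that measured step and possibly within the scatter. The step is estimated as a 1.6-fold lower number from compound 3 to compound 4 (0.20 log units; within the scatter). For compound 4 the expected value is 15000 nM, with an estimated range from 7000 nM to 30000 nM.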

Compound 4, half-maximal inhibitory concentration: 6170 nM
For compound 4 the middle estimate is 2.4-fold (0.39 log units) above the measured one, outside the stated range (below it).
By their numbers in this assay, from the lowest: compounds 4, 1 and 2 (each within the scatter of the next); then compound 3.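

In this assay, among the compounds shown here, chloro in place of fluoro on this aromatic carbon, ortho to a large group, gives a 3.8-fold lower number from compound 3 to compound 4 (0.58 log units; beyond the scatter) as the first direct reading of this exchange, and the change lies beyond the scatter. Hydrogen in place of chloro gives a 1.7-fold lower number from compound 2 to compound 4 (0.24 log units; within the scatter) and that step lies within the scatter, so the second chloro of the 2,6-dichlorophenyl group makes no difference that can be told here, and the 2-chlorophenyl group alone stands level with it. With the 2-chlorophenyl group held, hydroxy in place of 2-aminophenyl on an amide-type nitrogen gives a 1.0-fold lower number from compound 1 to compound 4 (0.01 log units; within the scatter) and that step also lies within the scatter, so the two groups cannot be told apart on this read-out.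

The compounds shown leave open whether bromo, methyl or methoxy on this carbon, or a plain phenyl group, would read like chloro or like fluoro, and whether the same exchange would count for anything in a compound carrying the 2-aminophenyl group. Nothing shown here gives a measured reason why chloro and fluoro differ at this position.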